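This account rests on a few compounds, and the source may have more. Where it says the series, first, only, none or still open, it means among the compounds named here.

Measured compounds:
- Compound 1, `Cc1ccc(C2CNN=C2S(=O)(=O)CC2=NCCS2)cc1`: 52.2%
- Compound 2, `Cc1ccc(-c2c[nH]nc2S(=O)(=O)CC2=NCCS2)cc1`: "not active" (no number reported)
- Compound 3, `Cc1ccc(C2CNN=C2S(=O)(=O)CC2=NCCO2)cc1`: 51.4%

In a functional assay, read by Griess assay, with a stated time of 150 min, tested at 100 ug/mL (a lower number here means a weaker effect, a higher number a stronger effect of the compound at the concentration tested), compound 1 gives 52.2% and compound 3 gives 51.4%. The two differ in one place: a group of 5 heavy atoms (3 carbon, 1 nitrogen, 1 oxygen; one five-membered non-aromatic ring with 2 hetero atoms) in place of a group of 5 heavy atoms (3 carbon, 1 nitrogen, 1 sulfur; one five-membered non-aromatic ring with 2 hetero atoms), on a saturated chain carbon bound to a sulfonyl sulfur. The step this made, a number 0.8 percentage points lower from compound 1 to compound 3 (within the scatter), shows that swapping one of these five-membered rings for the other left the read-out essentially where it was.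

Compound 2 shares much with compound 1 but rests on a different core; how the two cores differ is not broken down here. In this assay compound 2 is reported as "not active" (no number reported), so no number stands for it.

Compound 4, `Cc1ccc(-c2c[nH]nc2S(=O)(=O)CC2=NCCO2)cc1`, has not yet been measured. It stands to compound 2 as compound 3 stands to compound 1: a group of 5 heavy atoms (3 carbon, 1 nitrogen, 1 oxygen; one five-membered non-aromatic ring with 2 hetero atoms) in place of a group of 5 heavy atoms (3 carbon, 1 nitrogen, 1 sulfur; one five-membered non-aromatic ring with 2 hetero atoms), on a saturated chain carbon bound to a sulfonyl sulfur. This is the same change, at the same place. Since the earlier step was within the scatter, a step of similar, negligible size is expected from compound 2 to compound 4, which would keep compound 4 near the inactive level of compound 2. For compound 4 in this assay the read-out is therefore expected to be about 8%, roughly between 0% and 28%.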

Compound 4, a percentage reported as activity, at one concentration (the size of the read-out at that concentration, not a potency): 65.2%
Estimate against measurement, compound 4: 57.2 percentage points below; the whole stated range lies below it.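

Within the data shown here, compound 2 has no number in this assay, and no step from it to compound 4 can be read. The compounds shown leave open how large the ring swap is on the core of compound 2, and whether it matches the swap on the core of compound 1. Nothing shown here offers an explanation for the read-out of compound 4.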